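Three measured compounds point to an estimate for a fourth

A few compounds are considered here, and "the series" means these few. Any claim that something is new, unique, unknown or untested is made for them only; others in the source may bear on it.

- Compound 1 `COc1ccc(NS(=O)(=O)/C=C/c2c(OC)cc(OC)cc2OC)cc1` gives 75 nM
- Compound 2 `COC(=O)C(C)(C)Nc1cc(NS(=O)(=O)/C=C/c2c(OC)cc(OC)cc2OC)ccc1OC` gives 300 nM
- Compound 3 `COC(=O)C(Nc1cc(NS(=O)(=O)/C=C/c2c(OC)cc(OC)cc2OC)ccc1OC)c1ccc(Br)cc1` gives 1000 nM

In a functional assay on K562 cells (Homo sapiens) for cytotoxicity, read by trypan blue exclusion, with a stated time of 96 h (a lower number here means a stronger inhibitor, a higher number a weaker inhibitor), compound 3 has the highest number of the three at 1000 nM, which makes it the weakest inhibitor so far. Compound 4 `COc1cc(OC)c(/C=C/S(=O)(=O)Nc2ccc(OC)c(NC(C)C(=O)O)c2)c(OC)c1` has not yet been measured. Among the measured compounds shown here, its one structural change is 1-carboxyethyl in place of (4-bromophenyl)(methoxycarbonyl)methyl on a nitrogen on an aromatic ring. For the measured compounds named here, two measured steps bear on this change. The first is a 4.0-fold higher number from compound 1 to compound 2 (0.60 log units; beyond the scatter), seen when the (1-(methoxycarbonyl)-1-methylethyl)amino group replaced hydrogen on an aromatic carbon. The second is a 3.3-fold higher number from compound 2 to compound 3 (0.52 log units; beyond the scatter), seen when (4-bromophenyl)(methoxycarbonyl)methyl came in on the nitrogen. Compound 4 loses that group, so part of the second step may be undone, moving the number back towards compound 2 at 300 nM. Going by the values given here, no measured compound carries 1-carboxyethyl, so the uncertainty is wide. The expected change in this assay is a modest one towards a lower number, estimated as a 2.0-fold lower number from compound 3 to compound 4 (0.30 log units; within the scatter). For compound 4 the estimated value is 500 nM, with an expected range from 100 nM to 2500 nM.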

Compound 4, half-maximal inhibitory concentration: 8 nM
The estimate for compound 4 lay 63-fold (1.80 log units) above the measured number; measured number below the stated range.
By their numbers in this assay, from the lowest: compound 4; then compound 1; then compound 2; then compound 3.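

In this assay, among the compounds shown here, 1-carboxyethyl on the nitrogen gives a 130-fold lower number from compound 3 to compound 4 (2.10 log units; beyond the scatter) and a 38-fold lower number from compound 2 to compound 4 (1.57 log units; beyond the scatter), so the group carried at this place can shift the number far more than the earlier steps suggested. The earlier substituted compounds, compound 2 and compound 3, both had higher numbers than compound 1, yet this change gives a 9.4-fold lower number from compound 1 to compound 4 (0.97 log units; beyond the scatter), which shows that a group here can strengthen the compound as well as weaken it. Nothing shown explains this reversal.

Compound 4 differs from compound 2 and compound 3 both by having a carboxylic acid instead of a methyl ester and in the rest of the group, so these changes cannot be separated. From the compounds shown here alone, whether 1-(methoxycarbonyl)ethyl, the methyl ester of the same group, or a longer chain ending in a carboxylic acid would keep this strength remains open.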